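Replacing the furan of compound 3 with an aminopyridine

A few compounds are considered here, and "the series" means these few. Any claim that something is new, unique, unknown or untested is made for them only; others in the source may bear on it.

Of the compounds shown here, three sharing one core have been measured in an in vitro assay on HEK385-7 cells for displacement of a labelled ligand from prostaglandin D2 receptor 2 (Homo sapiens); on this read-out lower numbers stand for stronger inhibition and higher numbers for weaker inhibition. Compound 1 `O=C(O)Cc1sc(C(c2ccccc2)c2ccccc2)nc1-c1ccc(F)cc1` gives 8.7 nM. Compound 2 `O=C(O)Cc1sc(C(c2ccccc2)c2ccc(Cl)cc2)nc1-c1ccc(F)cc1`, which carries a chloro in place of hydrogen on an aromatic carbon, gives 14 nM; the step of a 1.6-fold higher number from compound 1 to compound 2 (0.21 log units; within the scatter) is within the scatter. Compound 3 `O=C(O)Cc1sc(C(c2ccc(F)cc2)c2ccc(F)cc2)nc1-c1ccoc1` gives 14 nM, level with compound 2 at the digits shown, so that the two together hold the highest numbers of the three, while the gap to compound 1 is also within the scatter.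

Compound 4 `O=C(O)Cc1sc(C(c2ccc(F)cc2)c2ccc(F)cc2)nc1-c1ccnc(N2CCC2)c1` has not yet been measured. It differs from compound 3 in one place: 2-(azetidin-1-yl)pyridin-4-yl in place of furan-3-yl on an aromatic carbon. Going by the values given here, the only measured step in the set, the one from compound 1 to compound 2, concerns a chloro on a different part of the molecule and says nothing about exchanging the group on the core. Among the compounds with values here, with no step bearing on this change, the expectation rests on the numbers of compound 3 alone and is correspondingly loose.

Compound 4 is therefore expected to give about 10 nM in this assay, within a range from 3 nM to 35 nM. The step of a 1.4-fold lower number from compound 3 to compound 4 (0.15 log units; within the scatter) is thus estimated to stay within the scatter, in either direction.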

Compound 4, half-maximal inhibitory concentration: 660 nM
Estimate against measurement, compound 4: 66-fold (1.82 log units) below; the whole stated range lies below it.
By their numbers in this assay, from the lowest: compounds 1, 2 and 3 (each within the scatter of the next); then compound 4.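

In this assay, exchanging furan-3-yl for 2-(azetidin-1-yl)pyridin-4-yl gives a 47-fold higher number from compound 3 to compound 4 (1.67 log units; beyond the scatter), so the group on this aromatic carbon, next to the ring nitrogen and next to the ring atom that bears a carboxymethyl group, can decide the result by a wide margin. Going by these compounds alone, the only earlier step concerned a chloro on a different part of the molecule and stayed within the scatter, so this is the first sign that the read-out responds strongly to a change in the shared core's substituents, and it comes at this position. Nothing at hand explains the loss, and the entering group differs from furan-3-yl in several ways at once, with a six-membered aromatic ring, a four-membered non-aromatic ring and 10 heavy atoms against 5.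

The compounds shown leave open whether the pyridine ring or the azetidine carries the step. A plain pyridin-4-yl, or a pyridine bearing a methoxy or dimethylamino group in place of the azetidine, would separate the two parts of this change.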